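The source may hold more compounds than are shown below. What is called first, only, known or untested is meant among the compounds shown, and "the series" means these compounds.

For the measured compounds named here, compound 1, with the structure `Cc1ccccc1-c1nnc(N(N)C(C)C)s1`, is the only compound here with a measured number: in a functional assay on the whole organism with Mus musculus as the target, in the maximal electroshock model, with a stated time of 1 h (a lower number here means that less compound is needed, a higher number that more compound is needed for the effect), compound 1 gives 54 mg/kg. Compound 2, with the structure `CC(C)N(N)c1nnc(-c2ccccc2-c2ccccc2)s1`, carries phenyl in place of methyl on an aromatic carbon. In this assay compound 2 gives > 100 mg/kg, which is a limit of the assay rather than a number. That is the limit of > 100 mg/kg in this assay, at which 1 of the 2 values shown sits. The step of an at least 1.8-fold higher number from compound 1 to compound 2 (0.26 log units; that floor lies within the scatter) is therefore known only as a floor.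

Compound 3, with the structure `Cc1ccccc1-c1nnc(N(C)NC(C)C)s1`, keeps the methyl on the aromatic carbon of compound 1 and changes the other side of the shared core: (isopropylamino)(methyl)amino in place of amino(isopropyl)amino on an aromatic carbon. Going by the values given here, the single measured step, from compound 1 to compound 2, alters a different part of the molecule and so offers no direct guide to this change. Among the compounds with values here, with no measured step at this position, a step near zero is expected, so that a 1.3-fold higher number from compound 1 to compound 3 (0.11 log units; within the scatter) means essentially no change beyond the scatter. Compound 3 is therefore estimated to give 70 mg/kg in this assay, within a range of 35 mg/kg to 140 mg/kg.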

Compound 3, dose for half-maximal effect: 35 mg/kg
The estimate for compound 3 lay 2.0-fold (0.30 log units) above the measured number; measured number inside the range.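

For the compounds shown here, this is the first measured step at the aromatic carbon next to the ring sulfur, where (isopropylamino)(methyl)amino takes the place of amino(isopropyl)amino. In this assay, the swap gives a 1.5-fold lower number from compound 1 to compound 3 (0.19 log units; within the scatter), so compound 1 and compound 3 cannot be told apart, even though a group of 6 heavy atoms replaces one of 5 and the two nitrogens are arranged differently. At this position, then, the move of the isopropyl group to the outer nitrogen together with the added methyl leaves the dose needed within the usual scatter, although nothing shown here explains why the result falls there.

As far as these compounds go, only these two closely related groups have been compared at this position, so it remains open how a ring amine such as morpholine, a longer chain such as butyl, or a carboxylic acid would behave there. From the compounds shown here alone, it is also open whether (isopropylamino)(methyl)amino would give a similar result on a core that carries the phenyl of compound 2 rather than the methyl of compound 1.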